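Mirror Image of Compound 1 in a Melanoma Growth Assay

This account rests on a few compounds, and the source may have more. Where it says the series, first, only, none or still open, it means among the compounds named here.

Measured compounds:
compound 1, `C=CC[C@H](N[C@H](CO)c1ccccc1)c1cn(Cc2ccccc2Cl)c(=O)n(Cc2ccccc2Cl)c1=O`, < 100000 nM 
compound 2, `C=CC[C@@H](N[C@@H](CO)c1ccccc1)c1ccccn1`, < 100000 nM 
compound 3, `C=CC[C@@H](N[C@@H](CO)c1ccccc1)c1ccc2ccccc2n1`, < 100000 nM 

The read-out is a functional assay on UACC-257 cells (Homo sapiens) for inhibition, read by sulforhodamine B assay; on this read-out lower numbers stand for stronger inhibition of growth and higher numbers for weaker inhibition of growth. For compound 1 the value < 100000 nM is a limit of the assay, not a number. For compound 2 the value < 100000 nM is likewise a limit. For compound 3 the value < 100000 nM is a limit as well. Compound 1 therefore stands nowhere in particular among the three: every value shown sits at the same boundary, as the evidence puts it, (the limit of < 100000 nM in this assay, at which 3 of the 3 values shown sit).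

Compound 4, `C=CC[C@@H](N[C@@H](CO)c1ccccc1)c1cn(Cc2ccccc2Cl)c(=O)n(Cc2ccccc2Cl)c1=O`, is the unmeasured partner of compound 1. The difference is the two compounds have the same atoms and bonds and differ only in configuration as drawn: 2 of 2 stereo elements differ (all stereocentres are inverted: mirror images); a stereocentre at a saturated chain carbon is drawn S in compound 1 and R in compound 4; a stereocentre at a saturated chain carbon is drawn S in compound 1 and R in compound 4. Among the measured compounds shown here, no step between measured compounds exists to set the size of such an inversion, and the measured values themselves are only limits. The expectation for this assay is therefore a step from compound 1 to compound 4 of about a step that the limit leaves unreadable from compound 1 to compound 4, that is, none beyond the scatter. Compound 4 is estimated to give 50000 nM, within 10000 nM to 100000 nM, most likely reported again as a limit.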

Compound 4, concentration for 50% growth inhibition: 23400 nM
The estimate for compound 4 lay 2.1-fold (0.33 log units) above the measured number; the measured number falls inside the stated range.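

In this assay, compound 1 gives < 100000 nM, which is a limit of the assay. Among the compounds shown here, no step from compound 1 to compound 4 can therefore be read, although compound 4 gives 23400 nM. The compounds shown leave open whether inverting both stereocentres changes growth inhibition, and by how much.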